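The source may hold more compounds than are shown below. What is called first, only, known or untested is meant among the compounds shown, and "the series" means these compounds.

Compound 1 `O=C(NO)C(F)(F)C(F)(F)C(F)(F)C(F)(F)C(F)(F)C(F)(F)C(=O)Nc1ccc(I)cc1` carries a 4-iodophenyl on the amide-type nitrogen of the shared core. In an ADME assay on isolated protein for inhibition of histone deacetylase 4 (Homo sapiens), read by fluorescence, with stated times of 30 min and 60 min (on this read-out higher numbers stand for weaker inhibition and lower numbers for stronger inhibition), compound 1 gives > 50000 nM, which is a limit of the assay and not a number. Compound 2 `O=C(NO)C(F)(F)C(F)(F)C(F)(F)C(F)(F)C(F)(F)C(F)(F)C(=O)Nc1cccc(-c2ccccc2)c1` carries a 3-phenylphenyl at the same place. In this assay compound 2 gives > 50000 nM, likewise only a limit. The step that the two limits leave unreadable from compound 1 to compound 2 is therefore unreadable, and both values sit at the limit of > 50000 nM in this assay, at which 2 of the 2 values shown sit, so compound 2 stands nowhere more precisely than at that limit. Compound 3 `O=C(NO)C(F)(F)C(F)(F)C(F)(F)C(F)(F)C(F)(F)C(F)(F)C(=O)Nc1ccccc1-c1ccccc1` is the next member, the change being (2-phenylphenyl in place of 3-phenylphenyl on an amide-type nitrogen). Among the compounds with values here, the single measured step bears on this change only in that it shows no readable inhibition on either side, so no step beyond the scatter is expected. The expected step is a step that the limit leaves unreadable from compound 2 to compound 3. Compound 3 is thus estimated at 100000 nM, within a range from 30000 nM to 300000 nM, and is expected most likely to be reported again as a limit.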

Compound 3, inhibition constant: > 50000 nM
Compound 3 ended at the assay's limit; the forecaster's own chance of this, stated with the estimate: 85%; the middle value does not contradict the limit.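

No new step can be read among compound 1, compound 2 and compound 3 in this assay, since each value is a limit of the assay and not a number: the limit of > 50000 nM in this assay, at which 3 of the 3 values shown sit.

The compounds shown leave open whether any group on the amide-type nitrogen gives a readable inhibition constant.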